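From Acetyl to Ethoxycarbonyl: One Small Swap

The source may hold more compounds than are shown below. What is called first, only, known or untested is meant among the compounds shown, and "the series" means these compounds.

Among the compounds with values here, in an ADME assay on HaCaT cells (Homo sapiens) for antiproliferative activity, with a stated time of 48 h (a lower number here means a stronger inhibitor, a higher number a weaker inhibitor), compound 2 `CCN(CC)c1ccc(-c2ccc(C(C)=O)cc2)nn1` gives 20000 nM as the only true number so far. Compound 1 `CCN(CC)c1ccc(-c2cccc(C#N)c2)nn1` reports > 25000 nM as a limit of the assay, not a number. Compound 3 `CCOC(=O)c1ccc(-c2ccc(N(CC)CC)nn2)cc1` differs from compound 2 by ethoxy in place of methyl on a carbonyl carbon, turning acetyl into ethoxycarbonyl. Within the data shown here, no measured step between two compounds exists to guide this change, so the expected shift a 1.1-fold higher number from compound 2 to compound 3 (0.04 log units; within the scatter) is none beyond the scatter, with neither direction favoured. Compound 3 is estimated at 22000 nM (expected range 10000 nM to 40000 nM).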

Compound 3, half-maximal inhibitory concentration: 500 nM
Estimate against measurement, compound 3: 44-fold (1.64 log units) above; measured number below the stated range.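

In this assay, within the data shown here, ethoxy in place of methyl on a carbonyl carbon gives a 40-fold lower number from compound 2 to compound 3 (1.60 log units; beyond the scatter), so what sits on this carbonyl carbon can matter greatly, which the earlier compounds could not show. Both ends of this step are true numbers. Compound 1 alone stands at a limit of the assay, not a number, so it offers no step: the limit of > 25000 nM in this assay, at which 1 of the 3 values shown sits.

As far as these compounds go, whether the oxygen or the ethyl chain of the ethoxy group carries this step stays open. A methoxycarbonyl or a propanoyl group in the same place could separate the two.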